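This account rests on a few compounds, and the source may have more. Where it says the series, first, only, none or still open, it means among the compounds named here.

Measured compounds:
compound 1 `C#Cc1cccc(Nc2ncnc3sc(NC(=O)/C=C/c4ccccc4)cc23)c1` — 58100 nM
compound 2 `O=C(/C=C/c1ccccc1)Nc1cc2ncnc(Nc3cc(Cl)cc(Cl)c3)c2s1` — 10700 nM
compound 3 `O=C(/C=C/c1ccc(O)cc1)Nc1cc2c(Nc3ccc(Cl)c(Cl)c3)ncnc2s1` — 42900 nM

All three share one core and were tested in a functional assay on HepG2 cells (Homo sapiens) for antiproliferative activity, read by MTT assay, with a stated time of 48 h; a higher number here means a weaker inhibitor, a lower number a stronger inhibitor. Compound 1 gives the highest number of the three. Its gap to compound 3 lies within the usual scatter of such measurements, so the two cannot be ranked against each other; compound 2, by contrast, gives a number clearly lower than compound 1, a gap beyond the scatter.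

The step now followed leads from compound 1 to compound 4 `O=C(/C=C/c1ccccc1)Nc1cc2c(Nc3cccc(Cl)c3F)ncnc2s1`, which has not yet been measured in this assay. The change is 3-chloro-2-fluorophenyl in place of 3-ethynylphenyl on a nitrogen on an aromatic ring. The cinnamamide part of compound 1 is kept unchanged.

Among the compounds with values here, no directly comparable pair among the measured compounds carries this exact change, so the expectation rests on the wider picture: the other compound with a halogenated ring on that nitrogen and the same cinnamamide is compound 2, and compound 2 gives 10700 nM, while compound 1 gives 58100 nM. A moderate step towards a lower number is therefore expected for compound 4, of the size a 2.9-fold lower number from compound 1 to compound 4 (0.46 log units; beyond the scatter). The estimate for compound 4 in this assay is 20000 nM, with a range from 6000 nM to 60000 nM.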

Compound 4, half-maximal inhibitory concentration: 44600 nM
Beside the measured number, compound 4's estimate is 2.2-fold (0.35 log units) below it; the measured number falls inside the stated range.
By their numbers in this assay, from the lowest: compound 2; then compounds 3, 4 and 1 (each within the scatter of the next).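

In this assay the exchange of 3-ethynylphenyl for 3-chloro-2-fluorophenyl on the nitrogen gives a 1.3-fold lower number from compound 1 to compound 4 (0.11 log units; within the scatter) and so leaves the read-out unchanged within the usual scatter. This position therefore accepts a ring carrying chlorine and fluorine in place of the ring carrying the ethynyl group, with no measurable gain or loss. Halogens on this ring are also not enough on their own to secure a low number: compound 4 gives 44600 nM and stays clearly short of compound 2, which gives 10700 nM and also carries a halogenated ring. Nothing available here explains why the ethynyl and chlorine-fluorine rings read alike or why compound 2 stands apart.

As far as these compounds go, it remains open whether a ring bearing a single chlorine would read like compound 2 or like compound 4. Also open, from the compounds shown here alone, is whether an amine or a carboxylic acid on this ring, or a plain alkyl chain in place of the ring on the nitrogen, would move the number at all.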